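The source may report more compounds than this note shows. Statements on the series, on what has been measured and on what is new or still open speak of the compounds shown alone.

The study concerns three measured compounds. Compound 1, `c1ccc(CC2CCN(Cc3nc4ccccc4[nH]3)CC2)cc1`, gives 2800 nM in an assay on membranes from brain for binding affinity to Adrenergic receptor alpha-1 (Rattus norvegicus); a lower number here means a stronger inhibitor, a higher number a weaker inhibitor. Compound 2, `c1ccc(Oc2ccc(Cc3nc4ccccc4[nH]3)cc2)cc1`, gives 4200 nM in this assay, the largest of the three numbers, although its gaps to compound 1 and to compound 3 are both within the scatter. Compound 3, `CCS(=O)(=O)Nc1ccc2[nH]c(Cc3ccc(Oc4ccccc4)cc3)nc2c1`, gives 2800 nM in this assay; the step of a 1.5-fold lower number from compound 2 to compound 3 (0.18 log units; within the scatter) is therefore no real change.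

Compound 4, `O=S(=O)(Nc1ccc2[nH]c(Cc3ccc(Oc4ccccc4)cc3)nc2c1)c1ccccc1`, is not yet measured. It differs from compound 2 by (phenylsulfonyl)amino in place of hydrogen on an aromatic carbon. For the measured compounds named here, the only measured step that bears on this is the one from compound 2 to compound 3, which also places a sulfonylamino group on the same aromatic carbon and gave a 1.5-fold lower number from compound 2 to compound 3 (0.18 log units; within the scatter), within the scatter. On that basis no step beyond the scatter is expected in this assay, perhaps a slightly lower number at most. The estimate for compound 4 is thus 2500 nM, with a range of 900 nM to 7000 nM, amounting to an expected step of a 1.7-fold lower number from compound 2 to compound 4 (0.23 log units; within the scatter).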

Compound 4, half-maximal inhibitory concentration: 14000 nM
Compound 4: middle estimate off by 5.6-fold (0.75 log units), on the low side; measured number above the stated range.
By their numbers in this assay, from the lowest: compounds 1, 3 and 2 (each within the scatter of the next); then compound 4.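

At this aromatic carbon in this assay, the group on the sulfonyl sulfur matters, although adding (ethylsulfonyl)amino brought no real change (a 1.5-fold lower number from compound 2 to compound 3 (0.18 log units; within the scatter)): adding (phenylsulfonyl)amino instead gives a 3.3-fold higher number from compound 2 to compound 4 (0.52 log units; beyond the scatter). Phenyl in place of ethyl on the sulfonyl sulfur gives a 5.0-fold higher number from compound 3 to compound 4 (0.70 log units; beyond the scatter), so among these compounds a sulfonylamino group does not by itself fix the outcome, and both steps are modest but beyond the scatter. Nothing available here explains why the phenyl-bearing compound gives the higher number.

As far as these compounds go, it remains open whether a benzyl or a propyl group on the sulfonyl sulfur would give a number closer to that of compound 3 or that of compound 4. From the compounds shown here alone, it is also open how an amine or a carboxylic acid on this aromatic carbon would compare with hydrogen.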